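From compound 3 to compound 4: one group exchanged

The compounds below may be only part of what the source reports. "The series", "measured", "known", "first", "only" and "open" are said of these compounds alone.

compound 1 (`Cc1ccc(NC(=O)c2cc(Oc3ccc(S(C)(=O)=O)cc3)cc(OC(C)C)c2)nc1`) : 4.4 10^-6 cm/s
compound 2 (`CC(C)Oc1cc(Oc2ccc(S(C)(=O)=O)cc2)cc(-c2ccnc(=O)[nH]2)c1`) : "not determined" (no result reported)
compound 3 (`Cc1cc(=O)[nH]c(-c2cc(Oc3ccc(S(C)(=O)=O)cc3)cc(OC(C)C)c2)n1`) : 4.8 10^-6 cm/s

These values come from an ADME assay on MDCK-II cells (Canis lupus familiaris) for permeability (a lower number here means that the compound crosses the layer more slowly, a higher number that the compound crosses the layer faster), where compound 2 has no number. Going by the values given here, compound 3 has no clear rank: the one measured step is a 1.1-fold higher number from compound 1 to compound 3 (0.04 log units; within the scatter) and it lies within the scatter.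

Compound 4 (`CC(C)Oc1cc(Oc2ccc(S(C)(=O)=O)cc2)cc(-c2ncc(Cl)c(=O)[nH]2)c1`) keeps the shared core and differs from compound 3 in one group: a group of 8 heavy atoms (4 carbon, 2 nitrogen, 1 oxygen, 1 chlorine; one six-membered aromatic ring with 2 hetero atoms) in place of a group of 8 heavy atoms (5 carbon, 2 nitrogen, 1 oxygen; one six-membered aromatic ring with 2 hetero atoms), on an aromatic carbon. The exchange takes place on an aromatic carbon of a six-membered aromatic ring of carbon only, meta to a large group and meta to an isopropoxy group. Both groups have 1 hydrogen-bond donor, 2 hydrogen-bond acceptors and no net charge.

Among the compounds with values here, the one measured step bears on this only loosely. Within the data shown here, it also exchanged one ring-bearing group for another, but no measured compound contains chlorine, so the data give no direct evidence for that atom. Compound 3 at 4.8 10^-6 cm/s is therefore the starting point. No change beyond the scatter is expected in this assay, and no direction is favoured: the estimated change is no change at the digits printed from compound 3 to compound 4 (within the scatter) for this exchange. Compound 4 is expected at 4.8 10^-6 cm/s, with an estimated range of 2.4 10^-6 cm/s to 9.6 10^-6 cm/s.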

Compound 4, apparent permeability: 8.3 10^-6 cm/s
Beside the measured number, compound 4's estimate is 1.7-fold (0.24 log units) below it, within the range that was stated.
By their numbers in this assay, from the lowest: compounds 1, 3 and 4 (each within the scatter of the next).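

Going by these compounds alone, on this aromatic carbon, this assay now has a group containing chlorine, an atom that no earlier compound held, and the exchange gives a 1.7-fold higher number from compound 3 to compound 4 (0.24 log units; within the scatter), so the chlorine-bearing group and the group it replaces cannot be told apart by this read-out. The comparison with the larger group of compound 1, whose aromatic ring has 1 hetero atom, gives a 1.9-fold higher number from compound 1 to compound 4 (0.28 log units; within the scatter), and this second step also stays inside the usual variation between repeats. With the earlier step of a 1.1-fold higher number from compound 1 to compound 3 (0.04 log units; within the scatter), all three groups with a number at this position lie within the scatter of one another, so none of these exchanges has yet produced a clear change in how fast a compound crosses the cell layer.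

Nothing among the data offers an explanation for these numbers. It remains open whether a carboxylic acid or an amine on this ring, or bromine in place of the chlorine, would give a step beyond the scatter, and whether a longer chain in place of the isopropoxy group, which all of these compounds share, would alter the picture.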